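Swapping the aryl group on the pyridazinone nitrogen

This account rests on a few compounds, and the source may have more. Where it says the series, first, only, none or still open, it means among the compounds named here.

Compound 3 `Cc1cc(=O)n(-c2ccccc2C(F)(F)F)nc1C(=O)Nc1ccc(Oc2ncnc3ccsc23)cc1` was tested in a functional assay on HepG2 cells (Homo sapiens) for cytotoxicity, read by MTT assay, with a stated time of 72 h (a higher number here means a weaker inhibitor, a lower number a stronger inhibitor), where it gives 9230 nM. Among the two numbers available it is the highest; the nearest is compound 1 `CNC(=O)c1cc(Oc2ccc(NC(=O)c3nn(-c4ccc(Br)cc4F)c(=O)cc3C)cc2F)ccn1`, which gives 2830 nM in this assay. Compound 2 `CNC(=O)c1cc(Oc2ccc(NC(=O)c3nn(-c4ccccc4F)c(=O)cc3C)cc2F)ccn1` reaches only the limit of this assay, > 40000 nM, so no number is known for it.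

Compound 4 `Cc1cc(=O)n(-c2ccc(F)cc2)nc1C(=O)Nc1ccc(Oc2ncnc3ccsc23)cc1` differs from compound 3 in one place: 4-fluorophenyl in place of 2-(trifluoromethyl)phenyl on an aromatic nitrogen. Among the compounds with values here, the only measured step that touches the ring on that same aromatic nitrogen is the one from compound 1 to compound 2, where an at least 14-fold higher number from compound 1 to compound 2 (1.15 log units; beyond the scatter); that step removed a halogen from the ring and weakened the effect strongly, reaching (the limit of > 40000 nM in this assay, at which 1 of the 3 values shown sits). The change to compound 4 is of a different kind, exchanging one halogen-bearing ring for another, so that step gives only a rough guide. Within the data shown here, no measured pair shows the exact exchange, so the direction is uncertain and the step could go either way.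

Compound 4 is therefore expected to give about 9000 nM in this assay, with a likely range from 2500 nM to 35000 nM. This estimate means an expected step of a 1.0-fold lower number from compound 3 to compound 4 (0.01 log units; within the scatter), which may not stand out from the scatter.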

Compound 4, half-maximal inhibitory concentration: 2110 nM
For compound 4 the middle estimate is 4.3-fold (0.63 log units) above the measured one, outside the stated range (below it).
By their numbers in this assay, from the lowest: compounds 4 and 1 (each within the scatter of the next); then compound 3. At a limit, above all of these: compound 2.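

With the rest of compound 3 held fixed, exchanging 2-(trifluoromethyl)phenyl for 4-fluorophenyl on the aromatic nitrogen gives in this assay a 4.4-fold lower number from compound 3 to compound 4 (0.64 log units; beyond the scatter), so a lower number, meaning a stronger effect on the cells, can be reached by replacing the whole aryl group. Within the data shown here, the only earlier step on this nitrogen, bromo replaced by hydrogen on the ring of a different core, ended at a limit of the assay; this exchange of one entire aryl group for another shows that the number responds to more than the loss of a single bromo group. Nothing in the data shown accounts for the size or direction of this new step.

This single step removes the trifluoromethyl group and brings in a fluorine at another ring position, so the separate contribution of each change remains unresolved. From the compounds shown here alone, it also remains open how the number would respond to an amine or a carboxylic acid on this ring, or to a longer chain on the nitrogen in place of the ring.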